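A few compounds are considered here, and "the series" means these few. Any claim that something is new, unique, unknown or untested is made for them only; others in the source may bear on it.

Measured so far:
compound 1 `COC(=O)c1ccc(C2SCC(=O)N2c2ccc(N3CCN(Cc4cc(OC)c(OC)c(OC)c4)CC3)cn2)c(OC)c1` with 41000 nM
compound 2 `COC(=O)c1ccc(C2SCC(=O)N2c2ccc(N3CCN(S(=O)(=O)c4ccccc4)CC3)cn2)c(OC)c1` with 52900 nM
compound 3 `COC(=O)c1ccc(C2SCC(=O)N2c2ccc(N3CCNCC3)cn2)c(OC)c1` with 19300 nM

The three compounds share one core and differ only in what sits on an amine nitrogen in a ring. In a functional assay on Jurkat cells (Homo sapiens) for antiproliferative activity, read by MTT assay and trypan blue exclusion, with a stated time of 72 h (on this read-out lower numbers stand for stronger inhibition and higher numbers for weaker inhibition), compound 2 gives 52900 nM, the highest of the three numbers. Compound 1 gives 41000 nM, which lies within the scatter of compound 2. Among the measured compounds shown here, compound 3 gives 19300 nM, and the one measured step, a 2.7-fold lower number from compound 2 to compound 3 (0.44 log units; beyond the scatter), shows that removing the phenylsulfonyl altogether leads to a modestly lower number.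

Compound 4 `COC(=O)c1ccc(C2SCC(=O)N2c2ccc(N3CCN(S(=O)(=O)c4c(C)cc(C)cc4C)CC3)cn2)c(OC)c1` keeps the sulfonyl and alters only the ring attached to it: 2,4,6-trimethylphenyl in place of phenyl on a sulfonyl sulfur. For the measured compounds named here, no measured pair shows what adding methyl groups to that ring does. The step of a 2.7-fold lower number from compound 2 to compound 3 (0.44 log units; beyond the scatter) concerns removal of the whole group rather than a change within it, so it offers no direction for this change. With nothing pointing either way, the step expected from compound 2 to compound 4 is a 1.0-fold higher number from compound 2 to compound 4 (0.02 log units; within the scatter), which stays within the scatter. Compound 4 is therefore estimated at 55000 nM in this assay, with a range from 20000 nM to 150000 nM.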

Compound 4, half-maximal inhibitory concentration: > 100000 nM
Compound 4: a limit, no number; the forecaster's own chance of this, stated with the estimate: 15%; middle value at least 1.8-fold (0.25 log units) away from the limit.
By their numbers in this assay, from the lowest: compound 3; then compounds 1 and 2 (each within the scatter of the next). At a limit, above all of these: compound 4.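

In this assay compound 4 reads as a limit of the assay, not as a number: the limit of > 100000 nM in this assay, at which 1 of the 4 values shown sits. Among the compounds shown here, changing only the ring on the sulfonyl sulfur gives an at least 1.8-fold higher number from compound 2 to compound 4 (0.27 log units; that floor lies within the scatter); this is the first measured change within the sulfonyl group, but its true size is unknown, and because that floor lies within the scatter, this step alone does not separate the two compounds. Comparison with the free amine is clearer, since the full replacement of hydrogen on the ring nitrogen gives an at least 5.1-fold higher number from compound 3 to compound 4 (0.71 log units; beyond the scatter), so the (2,4,6-trimethylphenyl)sulfonyl group sits firmly on the side of the higher numbers, as the phenylsulfonyl group also did in its smaller step from the free amine.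

The compounds shown leave open how much of this shift needs all three methyl groups, and a ring with a single methyl, a methoxy or a chlorine would help to show this. They also leave open whether a small group on the same nitrogen, such as acetyl or a plain methyl, would give a number closer to that of compound 3.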